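This account rests on a few compounds, and the source may have more. Where it says the series, first, only, none or still open, it means among the compounds named here.

Measured so far:
- compound 1, `CC(C)c1onc(-c2c(Cl)cccc2Cl)c1COc1ccc(-c2nc3ccc(C(=O)O)cc3n2CC2CC2)cc1`: 19.4 nM
- compound 2, `CC(C)c1onc(-c2c(Cl)cccc2Cl)c1COc1ccc(-c2nc3ccc(C(=O)O)cc3n2C)cc1Cl`: 19 nM

Both compounds were read in an assay on Huh-7 cells for agonist activity at Bile acid receptor (Homo sapiens), read by a luciferase reporter; a lower number here means that less compound is needed, a higher number that more compound is needed for the effect. Compound 1 gives 19.4 nM and compound 2 gives 19 nM; the two numbers sit within the usual scatter of each other, so no order between them can be drawn, and compound 1 simply has the higher of the two numbers. For the measured compounds named here, no pair that differs in one place has been measured, so there is no step to lean on.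

Compound 3, `CC(C)c1onc(-c2c(Cl)cccc2Cl)c1COc1ccc(-c2nc3ccc(C(=O)O)cc3n2C2CCCC2)cc1`, remains to be measured in this assay. It differs from compound 1 as follows: cyclopentyl in place of cyclopropylmethyl on an aromatic nitrogen. The group on the aromatic nitrogen stays a small saturated carbon ring system with no donors or acceptors and no charge, so the step from compound 1 to compound 3 is expected to stay within the scatter, with no clear direction.

Compound 3 is therefore estimated at 20 nM, in the range 8 nM to 50 nM, which means an expected step of a 1.0-fold higher number from compound 1 to compound 3 (0.01 log units; within the scatter).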

Compound 3, half-maximal effective concentration: 13.6 nM
Beside the measured number, compound 3's estimate is 1.5-fold (0.17 log units) above it; measured number inside the range.
By their numbers in this assay, from the lowest: compounds 3, 2 and 1 (each within the scatter of the next).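

For the compounds shown here, on the aromatic nitrogen of the five-membered aromatic ring, the first one-place comparison, cyclopentyl in place of cyclopropylmethyl, gives in this assay a 1.4-fold lower number from compound 1 to compound 3 (0.15 log units; within the scatter) and so sets no order between these two groups. For compound 1 and compound 3, a saturated carbon ring on this nitrogen keeps the number within the scatter whether it is cyclopropylmethyl or cyclopentyl. No measurement on hand bears on why this step is small.

Open, as far as these compounds go, is whether this nitrogen keeps the number in the same range with an amine, a hydroxyl group, a phenyl ring or a longer chain such as n-butyl. Compound 2 differs from compound 1 and compound 3 in more than one place, so the parts played by its methyl and its extra chlorine cannot be separated.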